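One Methyl Fewer on a Basic Amine

The source may hold more compounds than are shown below. What is called first, only, known or untested is meant among the compounds shown, and "the series" means these compounds.

Of the compounds shown here, two sharing one core have been tested in a functional assay on PC-6 cells (Homo sapiens) for cytotoxicity, read by MTT assay, with a stated time of 3 days; on this read-out lower numbers stand for stronger inhibition and higher numbers for weaker inhibition. Compound 1, `CN(C)Cc1ccc(/C=N/Nc2ncnc3sc(C(C)(C)C)cc23)cc1`, gives 0.107 ug/mL. Compound 2, `CN1Cc2ccc(/C=N/Nc3ncnc4sc(C(C)(C)C)cc34)cc2C1`, gives 0.05 ug/mL. Of these two numbers, compound 1 has the higher one and compound 2 the lower, and the gap between them is beyond the usual scatter. Compound 3, `CNCc1ccc(/C=N/Nc2ncnc3sc(C(C)(C)C)cc23)cc1`, has not yet been measured. It differs from compound 1 in a single place: hydrogen in place of methyl on an amine nitrogen. Among the measured compounds shown here, no measured pair shows the effect of this particular change on its own, so the expectation rests on the change being the loss of one methyl and on compound 1 giving 0.107 ug/mL. The step of a 1.1-fold higher number from compound 1 to compound 3 (0.05 log units; within the scatter) is expected to stay within the scatter. The estimated value for compound 3 in this assay is 0.12 ug/mL, with a range from 0.05 ug/mL to 0.3 ug/mL.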

Compound 3, half-maximal inhibitory concentration: 0.044 ug/mL
Beside the measured number, compound 3's estimate is 2.7-fold (0.44 log units) above it; the measured number lies below the stated range.
By their numbers in this assay, from the lowest: compounds 3 and 2 (each within the scatter of the next); then compound 1.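

Taking one methyl off the amine nitrogen gives, in this assay, a 2.4-fold lower number from compound 1 to compound 3 (0.39 log units; beyond the scatter) and so, on this read-out, stronger inhibition. Among the compounds shown here, this is the first measured view of this change on its own, and it shows that the cells' response is sensitive to the loss of a single carbon at this nitrogen, with the dimethylamino group giving way to the methylamino group. Nothing available explains why the number falls, so the step stands as an observation only. On these data alone, whether the trend would continue with a primary amine, which carries no methyl at all, or would turn back with a longer chain such as ethyl on the same nitrogen remains open. One step also cannot show whether this change would act the same way on a different core.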